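A few compounds are considered here, and "the series" means these few. Any claim that something is new, unique, unknown or untested is made for them only; others in the source may bear on it.

Compound 1 `O=C1NCCN(c2cccc(Cl)c2)N1` is the starting point. In a functional assay on cells for inhibition of Polyunsaturated fatty acid 5-lipoxygenase (Homo sapiens) (on this read-out higher numbers stand for weaker inhibition and lower numbers for stronger inhibition), compound 1 gives 2100 nM. Compound 2 `CC1CN(c2cccc(Cl)c2)NC(=O)N1` carries one change from compound 1 methyl in place of hydrogen on a saturated ring carbon and in this assay compound 2 gives 2700 nM, so that a 1.3-fold higher number from compound 1 to compound 2 (0.11 log units; within the scatter).

Compound 3 `COc1cccc(N2CCNC(=O)N2)n1` has a different core; the difference between the two cores is not broken down here. In this assay compound 3 gives 3500 nM, and its value and that of compound 1 lie within the scatter of each other.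

Compound 4 `COc1cccc(N2CC(C)NC(=O)N2)n1` differs from compound 3 by methyl in place of hydrogen on a saturated ring carbon. This is the same kind of change as from compound 1 to compound 2, but the ring atom two ring bonds away bears a group of 8 heavy atoms rather than 7. The expected step is a 1.2-fold higher number from compound 3 to compound 4 (0.09 log units; within the scatter), resting on a 1.3-fold higher number from compound 1 to compound 2 (0.11 log units; within the scatter). Compound 4 is therefore estimated at 4300 nM, between 2200 nM and 8500 nM.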

Compound 4, half-maximal inhibitory concentration: 7100 nM
The estimate for compound 4 lay 1.7-fold (0.22 log units) below the measured number; the range from low to high includes it.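

In this assay, methyl in place of hydrogen on a saturated ring carbon gives a 2.0-fold higher number from compound 3 to compound 4 (0.31 log units; beyond the scatter). Set beside the earlier step on the core of compound 1, this step differs by no more than repeat measurements would allow, so the change carries over between these two cores as far as can be told: the same change on two cores in this assay, a 1.3-fold higher number (0.11 log units; within the scatter) from compound 1 to compound 2 and a 2.0-fold higher number (0.31 log units; beyond the scatter) from compound 3 to compound 4, 1.6-fold (0.20 log units) apart, within the scatter of two such steps. Two pairs do not show that the step would hold on any other core, and they do not establish a real difference between these two cores.

Going by these compounds, whether an ethyl group, a longer chain or an amine on the same saturated ring carbon would shift the number further remains open. So does the size of the methyl step on a third core.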